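Notes on the series: from acetyl ester to free hydroxy

This account rests on a few compounds, and the source may have more. Where it says the series, first, only, none or still open, it means among the compounds named here.

Measured compounds:
Compound 1, `CCO[C@@H](C1=CC2C(c3ccc(OC)cc3)=NN(c3ccccc3)C2N=C1)[C@H](OC)[C@@H](O)COC`: in a functional assay on THP-1 cells (Homo sapiens) for inhibition, read by ELISA, tested at 10 uM (a lower number here means less inhibition, a higher number more inhibition at the concentration tested (going by the name of the read-out)), compound 1 gives 35%.
Compound 2, `Cc1nn(-c2ccccc2)c2ncc(CCCO)cc12`: in this assay compound 2 gives 19%.
Compound 3, `CCn1ncc2cc(CCCOC(C)=O)cnc21`: in this assay compound 3 gives 16%.

Compound 3 sits at the bottom of the three numbers. Its gap to compound 2 lies within the usual scatter, so these two cannot be put in order; the gap to compound 1 lies beyond the scatter, and compound 1 is the only one of the three that stands clearly apart from compound 3.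

Compound 4, `CCn1ncc2cc(CCCO)cnc21`, has not yet been measured in this assay. It follows from compound 3 by one change: hydrogen in place of acetyl on an oxygen on a saturated carbon. Compound 2 also carries a hydroxy group and gives 19%, which falls within the scatter of the number for compound 3. For the measured compounds named here, no step between two measured compounds exists here, so this change has no direct precedent. In this assay the expected step is a number 2 percentage points higher from compound 3 to compound 4 (within the scatter), not beyond the scatter in either direction.

Compound 4 is estimated at 18%, with a range from 6% to 32%.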

Compound 4, a percentage reported as inhibition, at one concentration (the size of the read-out at that concentration, not a potency): 45%
For compound 4 the middle estimate is 27 percentage points below the measured one; the measured number lies above the stated range.
By their numbers in this assay, from the lowest: compounds 3 and 2 (each within the scatter of the next); then compounds 1 and 4 (each within the scatter of the next).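

In this assay, for the compounds shown here, hydrogen in place of acetyl on an oxygen on a saturated carbon gives a number 29 percentage points higher from compound 3 to compound 4 (beyond the scatter) and provides the first direct reading of this change. It shows that the number at this position depends on what sits on the oxygen: acetoxy to hydroxy is a real step here, while compound 2, which also carries a hydroxy group, differs from compound 4 in more than one place and could not show this. Nothing at hand explains the step.

Still open, on these data alone, is whether the higher number belongs to the free hydroxy itself or follows from the loss of acetyl alone, and a methyl ether on the same oxygen, an amine or a carboxylic acid in its place, or a longer chain carrying the hydroxy would help separate these readings. Going by these compounds alone, also open is whether the same change gives a step of similar size on the core of compound 2 or compound 1, since this series offers only one matched pair, and a single pair cannot establish a pattern.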